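A few compounds are considered here, and "the series" means these few. Any claim that something is new, unique, unknown or untested is made for them only; others in the source may bear on it.

Working notes on the series, intrinsic activity.

Two compounds of the shared core carry numbers in an assay on isolated protein with 5-hydroxytryptamine receptor 1B (Homo sapiens) as the target; a higher number here means a larger maximal response, a lower number a smaller maximal response. Compound 1 `COc1cc2c(cc1N1C[C@@H](C)N(C)[C@@H](C)C1)N(C(=O)Nc1cccc(Cl)c1Cl)CC2` gives 0.1 in this assay, and compound 2 `COc1cc2c(cc1N1C[C@@H](C)N(C)[C@@H](C)C1)N(C(=O)c1ccc(-c3cccc(C)n3)c3ccccc13)CC2` gives 0.3 in this assay. Among the compounds with values here, compound 1 stands lowest of the two, with compound 2 its only neighbour and the gap beyond the usual scatter. Within the data shown here, the two differ at more than one place, so no single step between them is set down; their two values show only that compound 2 reaches the larger maximal response.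

Compound 3 `COc1cc2c(cc1N1C[C@@H](C)N(C)[C@@H](C)C1)N(C(=O)Nc1cccc(C(F)(F)F)c1F)CC2` is next to be measured in this assay. Against compound 1 the change is 2-fluoro-3-(trifluoromethyl)phenyl in place of 2,3-dichlorophenyl on an amide-type nitrogen. The entering group keeps one six-membered aromatic ring of carbon only, without hydrogen-bond donors or acceptors, and stays on the amide-type nitrogen. Among the measured compounds shown here, no measured pair shows what exchanging chlorine for fluorine and trifluoromethyl on such a ring does here, so the step size rests on compound 1 alone. A step of a number 0.050 higher from compound 1 to compound 3 (within the scatter) is expected, none beyond the scatter, because compound 1 already gives 0.1 near the bottom of the range. Compound 3 is accordingly estimated at 0.15, within 0 to 0.35.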

Compound 3, intrinsic activity: the largest response reached, as a fraction of the reference agonist's: 0
Beside the measured number, compound 3's estimate is 0.15 above it; measured number inside the range.
By their numbers in this assay, from the lowest: compounds 3 and 1 (each within the scatter of the next); then compound 2.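

In this assay, within the data shown here, 2-fluoro-3-(trifluoromethyl)phenyl in place of 2,3-dichlorophenyl on the amide-type nitrogen gives a number 0.10 lower from compound 1 to compound 3 (within the scatter), the first step that can be read at a single place. At this position, then, the two substituted phenyl groups are not separated by maximal response, even though the entering group has more heavy atoms and carries fluorine alone where the leaving group carries chlorine. No measurement shown here speaks to the reason for this result, and the step is recorded as an observation only.

Still open, as far as these compounds go, is whether an amine or a carboxylic acid on this phenyl ring, or a pyridine ring or a longer alkyl chain in its place on the amide-type nitrogen, would move the maximal response beyond the scatter. This one step also says nothing about the rest of the shared core, for instance what a hydroxyl group in place of the methoxy group would do to the read-out in this assay.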